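Swapping a butyl carbamate for a phenyl carbamate

The source may report more compounds than this note shows. Statements on the series, on what has been measured and on what is new or still open speak of the compounds shown alone.

The compounds here share one core, a selenocyanate-bearing aromatic ring carrying a carbamate. Compound 1 `CCCCOC(=O)Nc1ccc([Se]C#N)cc1` carries a butyl group on the carbamate oxygen. In a functional assay on CCRF-CEM cells (Homo sapiens) for cytotoxicity, read by MTT assay, with a stated time of 72 h (on this read-out higher numbers stand for weaker inhibition of growth and lower numbers for stronger inhibition of growth), compound 1 gives 27900 nM. Among the compounds with values here, only one other compound has been measured: compound 2 `N#C[Se]c1ccc(NC(=O)OCc2ccc([N+](=O)[O-])cc2)cc1`, which bears a nitrobenzyl group in the same position, and in this assay compound 2 gives 38300 nM. These two numbers lie within the scatter of each other, so neither compound can be said to inhibit growth more strongly than the other; compound 1 simply shows the smaller of the two numbers.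

Compound 3 `N#C[Se]c1ccc(NC(=O)Oc2ccccc2)cc1` differs from compound 1 in one place: phenyl in place of butyl on an oxygen next to a carbonyl group. Within the data shown here, nothing measured so far links a butyl group to a phenyl group on this oxygen, so the size of the step cannot be read off from existing data. Given that compound 1 and compound 2 agree within the scatter despite rather different groups on the oxygen, the expected step from compound 1 to compound 3 is small, a 1.1-fold lower number from compound 1 to compound 3 (0.05 log units; within the scatter), with no direction beyond the scatter. Compound 3 is therefore estimated at 25000 nM, within a range from 10000 nM to 60000 nM.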

Compound 3, concentration for total growth inhibition: 48000 nM
Beside the measured number, compound 3's estimate is 1.9-fold (0.28 log units) below it; low and high end bracket the measured number.
By their numbers in this assay, from the lowest: compounds 1, 2 and 3 (each within the scatter of the next).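

Putting phenyl in place of butyl on an oxygen next to a carbonyl group gives a 1.7-fold higher number from compound 1 to compound 3 (0.24 log units; within the scatter) in this assay. Within the data shown here, this is the first direct reading of a single change at this place, and it replaces butyl, a chain with no ring, with a six-membered aromatic ring of carbon only, yet compound 1 and compound 3 cannot be told apart on this read-out. The step therefore gives no sign that growth inhibition depends on which of these two groups sits here, though a single pair cannot rule out a small effect hidden within the scatter, and nothing available bears on the reason for this result.

The compounds shown all carry a carbon-only group or a nitrobenzyl group on this oxygen, so it stays open whether a much longer chain, or a group holding an amine or a carboxylic acid, would give a step beyond the scatter. As far as these compounds go, it is equally open whether the selenocyanate or the carbamate itself matters, since both stay the same in every compound here.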